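The compounds below may be only part of what the source reports. "The series", "measured", "known", "first", "only" and "open" are said of these compounds alone.

In a functional assay for inhibition, with Homo sapiens as the target; a higher number here means a weaker inhibitor, a lower number a stronger inhibitor:
Compound 1 `CC(O)c1cc(-c2ccccc2)c2ccc(OCc3cccc(C4(O)CCOCC4)c3)cc2c1`: 28 nM
Compound 2 `CC(=O)c1cc(-c2ccccc2)c2ccc(OCc3cccc(C4(O)CCOCC4)c3)cc2c1`: 2 nM
Compound 3 `OC1(c2cccc(COc3ccc4c(-c5ccccc5)cc(-c5nn[nH]n5)cc4c3)c2)CCOCC1`: > 700 nM, a limit and not a number

Compound 3 therefore stands at the limit of this assay, with no measured number of its own. Compound 4 `Cn1nnc(-c2cc(-c3ccccc3)c3ccc(OCc4cccc(C5(O)CCOCC5)c4)cc3c2)n1` differs from it by methyl in place of hydrogen on an aromatic nitrogen. Among the measured compounds shown here, no measured step covers this change directly. The nearest are an at least 25-fold higher number from compound 1 to compound 3 (1.39 log units; beyond the scatter) and an at least 350-fold higher number from compound 2 to compound 3 (2.54 log units; beyond the scatter), both large and both introducing 2H-tetrazol-5-yl, while a 14-fold lower number from compound 1 to compound 2 (1.15 log units; beyond the scatter) is also large. The substituent on this aromatic carbon thus matters strongly, and a large drop is expected, though with much uncertainty. The expected change is an at least 28-fold lower number from compound 3 to compound 4 (1.44 log units; beyond the scatter). For compound 4 the estimated value is 25 nM, with an expected range of 4 nM to 150 nM.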

Compound 4, half-maximal inhibitory concentration: 4 nM
Compound 4: the middle estimate sits 6.3-fold (0.80 log units) above what was measured, within the range that was stated.
By their numbers in this assay, from the lowest: compounds 2 and 4 (each within the scatter of the next); then compound 1. At a limit, above all of these: compound 3.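

In this assay, a tetrazole can serve on this aromatic carbon once it carries a methyl: methyl in place of hydrogen on an aromatic nitrogen gives an at least 170-fold lower number from compound 3 to compound 4 (2.24 log units; beyond the scatter). Compound 3 has a limit and not a number: the limit of > 700 nM in this assay, at which 1 of the 4 values shown sits. The 2-methyl-2H-tetrazol-5-yl group stands level with acetyl, with a 2.0-fold higher number from compound 2 to compound 4 (0.30 log units; within the scatter), and ahead of 1-hydroxyethyl, with a 7.0-fold lower number from compound 1 to compound 4 (0.85 log units; beyond the scatter). On these data alone, what an ethyl group or a longer chain on that ring nitrogen would give stays open. So does the effect of a carboxylic acid or an amide on the aromatic carbon.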